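Chloro for Fluoro on the Urea Aryl Ring

This account rests on a few compounds, and the source may have more. Where it says the series, first, only, none or still open, it means among the compounds named here.

Measured compounds:
compound 1, `CN(C)CCNc1nc(-c2ccc(NC(=O)Nc3ccc(F)cc3)cc2)nc2ccsc12`: 390 nM
compound 2, `CN(C)CCNc1nc(-c2ccc(NC(=O)Nc3ccc(Cl)cc3)cc2)nc2ccsc12`: 130 nM
compound 3, `CCN(CC)CCCNc1nc(-c2ccc(NC(=O)Nc3ccc(F)cc3)cc2)nc2ccsc12`: 290 nM

In a functional assay on NCI-H460 cells (Homo sapiens) for cytotoxicity, read by MTT assay, with a stated time of 72 h (a lower number here means a stronger inhibitor, a higher number a weaker inhibitor), compound 3 gives 290 nM, the second highest of the three numbers. The value of compound 1 lies within the scatter of that of compound 3, which is borne out by a 1.3-fold lower number from compound 1 to compound 3 (0.13 log units; within the scatter). Compound 2, by contrast, gives a clearly lower number than compound 3.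

Compound 4, `CCN(CC)CCCNc1nc(-c2ccc(NC(=O)Nc3ccc(Cl)cc3)cc2)nc2ccsc12`, is compound 3 with one change: chloro in place of fluoro on an aromatic carbon. The same exchange has already been measured once, on the dimethylamino chain, as a 3.0-fold lower number from compound 1 to compound 2 (0.48 log units; beyond the scatter), a modest step beyond the scatter. Since the chain change itself, a 1.3-fold lower number from compound 1 to compound 3 (0.13 log units; within the scatter), stayed within the scatter, the two changes seem to act independently, and the chloro step is expected to carry over to the diethylamino chain. For compound 4 the expected step is therefore a 2.9-fold lower number from compound 3 to compound 4 (0.46 log units; beyond the scatter) in this assay, a lower number. Compound 4 is estimated at 100 nM, with a range from 45 nM to 220 nM.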

Compound 4, half-maximal inhibitory concentration: 81 nM
For compound 4 the middle estimate is 1.2-fold (0.09 log units) above the measured one, and the stated range covers the measured number.
By their numbers in this assay, from the lowest: compounds 4 and 2 (each within the scatter of the next); then compounds 3 and 1 (each within the scatter of the next).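

On the diethylamino chain, chloro in place of fluoro on the aromatic carbon gives a 3.6-fold lower number from compound 3 to compound 4 (0.55 log units; beyond the scatter) in this assay, so the step first seen on the dimethylamino chain recurs on a second chain, and the two readings agree: the same change on two cores in this assay, a 3.0-fold lower number (0.48 log units; beyond the scatter) from compound 1 to compound 2 and a 3.6-fold lower number (0.55 log units; beyond the scatter) from compound 3 to compound 4, 1.2-fold (0.08 log units) apart, within the scatter of two such steps.

With chloro on the ring, the chain change gives a 1.6-fold lower number from compound 2 to compound 4 (0.21 log units; within the scatter) and so matches its reading with fluoro: the same change on two cores in this assay, a 1.3-fold lower number (0.13 log units; within the scatter) from compound 1 to compound 3 and a 1.6-fold lower number (0.21 log units; within the scatter) from compound 2 to compound 4, 1.2-fold (0.08 log units) apart, within the scatter of two such steps.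

Across these four compounds, the halogen exchange moves the number beyond the scatter while the chain exchange does not, and no compound goes against this.

The compounds shown leave open whether the trend continues with bromo or trifluoromethyl at the same place on the ring. They also leave open how a cyclic amine such as morpholine at the end of the chain would read.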